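Bromo in place of chloro on the anilide ring

The source may hold more compounds than are shown below. What is called first, only, known or untested is meant among the compounds shown, and "the series" means these compounds.

Compound 3 `CN(C)C(=O)c1cc2cnc(Nc3ccc(NC(=O)C4(C(=O)Nc5cccc(Cl)c5)CC4)cc3)nc2n1C1CCCC1` is tested in a functional assay on SiHa cells (Homo sapiens) for inhibition, read by CCK-8 assay, with a stated time of 72 h, tested at 1 uM (on this read-out lower numbers stand for less inhibition of growth and higher numbers for more inhibition of growth at the one concentration tested), and gives 16.2%. Among the three measured compounds it stands second highest: compound 1 `CN(C)C(=O)c1cc2cnc(Nc3ccc(NC(=O)C4(C(=O)Nc5ccc(F)cc5)CC4)cc3)nc2n1C1CCCC1` gives 36.5%, and compound 2 `CN(C)C(=O)c1cc2cnc(Nc3ccc(NC(=O)C4(C(=O)Nc5ccc(Cl)cc5)CC4)cc3)nc2n1C1CCCC1` gives -0.8%. The step from compound 1 to compound 2, chloro in place of fluoro on an aromatic carbon, is a number 37.3 percentage points lower from compound 1 to compound 2 (beyond the scatter), while a number 17 percentage points higher from compound 2 to compound 3 (beyond the scatter) and a number 20.3 percentage points lower from compound 1 to compound 3 (beyond the scatter) are more modest.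

Compound 4 `CN(C)C(=O)c1cc2cnc(Nc3ccc(NC(=O)C4(C(=O)Nc5cccc(Br)c5)CC4)cc3)nc2n1C1CCCC1` differs from compound 3 in one place: bromo in place of chloro on an aromatic carbon. Among the measured compounds shown here, no measured step swaps one halogen for another on a carbon meta to a large group, so the nearest guide is the large drop seen from compound 1 to compound 2, where a heavier halogen replaced a lighter one. By that guide a lower number is expected, yet the scale of that drop need not carry over. Compound 4 is therefore estimated at 8%, within -15% to 30%, a step of a number 8.2 percentage points lower from compound 3 to compound 4 (within the scatter) that may or may not exceed the scatter.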

Compound 4, percent growth inhibition at one concentration: 13.9%
Compound 4: middle estimate off by 5.9 percentage points, on the low side; the measured number falls inside the stated range.
By their numbers in this assay, from the lowest: compound 2; then compounds 4 and 3 (each within the scatter of the next); then compound 1.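

In this assay, the exchange of chloro for bromo gives a number 2.3 percentage points lower from compound 3 to compound 4 (within the scatter), so on this carbon the two halogens cannot be told apart, whereas the step from 4-fluorophenyl to 4-chlorophenyl was a number 37.3 percentage points lower from compound 1 to compound 2 (beyond the scatter). The 3-bromophenyl compound also sits clearly between the two compounds with a halogen on the 4-position, with a number 14.7 percentage points higher from compound 2 to compound 4 (beyond the scatter) and a number 22.6 percentage points lower from compound 1 to compound 4 (beyond the scatter). Nothing available explains why chloro and bromo read alike here.

Going by these compounds, it remains open whether 3-fluorophenyl would read like these two compounds or nearer to compound 1. On these data alone, it is also open whether a group that is not a halogen on the same carbon, such as methoxy, an amine or a nitrile, would move the number beyond the scatter.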